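The compounds below may be only part of what the source reports. "The series", "measured", "known", "first", "only" and "open" are said of these compounds alone.

Compound 3 `COc1ccc(Cl)cc1N(CC(=O)Nc1ccc(C(F)(F)F)cc1)S(=O)(=O)c1ccccc1` gives 3750 nM in a functional assay on SH-SY5Y cells (Homo sapiens), read by MTT assay, with a stated time of 24 h; on this read-out lower numbers stand for an effect already at smaller amounts and higher numbers for an effect only at larger amounts of compound. Compound 1 `CCn1ccc2cc(NC(=O)CN(c3cc(Cl)ccc3OC)S(=O)(=O)c3ccccc3)ccc21` gives 2220 nM in this assay, and the step of a 1.7-fold higher number from compound 1 to compound 3 (0.23 log units; within the scatter) stays within the scatter, so the two numbers cannot be ranked. Compound 2 `COc1ccc(Cl)cc1N(CC(=O)N1CCc2ccccc21)S(=O)(=O)c1ccccc1` reaches only a limit of the assay, > 20000 nM. The unmeasured compound 4 `CCN(CC)C(=O)CN(c1cc(Cl)ccc1OC)S(=O)(=O)c1ccccc1` differs from compound 3 by diethylamino in place of (4-(trifluoromethyl)phenyl)amino on a carbonyl carbon. Going by the values given here, one measured step bears on this place: an at least 5.3-fold lower number from compound 2 to compound 3 (0.72 log units; beyond the scatter), in which an anilide took the place of a cyclic tertiary amide and the number came down from the limit. The change from compound 3 to compound 4 runs the other way, from an anilide to an open tertiary amide, so a step of similar size back upward is the natural expectation. The expected step is therefore a rise, a 4.0-fold higher number from compound 3 to compound 4 (0.60 log units; beyond the scatter). Since compound 2 sits at the limit of > 20000 nM in this assay, at which 1 of the 3 values shown sits, compound 4 may likewise be reported only as a limit. Compound 4 is expected to give about 15000 nM in this assay, in a range from 5000 nM to 40000 nM.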

Compound 4, half-maximal effective concentration: > 20000 nM
Compound 4: no number, only a limit; the forecaster's own chance of this, stated with the estimate: 50%; at least 1.3-fold (0.12 log units) between middle value and limit.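

Putting diethylamino in place of (4-(trifluoromethyl)phenyl)amino on the carbonyl carbon gives an at least 5.3-fold higher number from compound 3 to compound 4 (0.72 log units; beyond the scatter) in this assay, so the loss seen with the 2,3-dihydro-1H-indol-1-yl group of compound 2 also occurs with a tertiary amide that has no ring. Compound 2 and compound 4, the two compounds without the amide hydrogen, both stand at a limit and not at a number: the limit of > 20000 nM in this assay, at which 2 of the 4 values shown sit. The two limits leave the step between compound 2 and compound 4 unreadable, so these compounds cannot be ranked.

The compounds shown leave open whether the amide hydrogen or the aromatic ring matters here, as compound 4 changes both at once. A secondary amide carrying ethylamino, or an anilide with a methyl group on its nitrogen, would separate the two.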